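Ester branching and the step to compound 4

This account rests on a few compounds, and the source may have more. Where it says the series, first, only, none or still open, it means among the compounds named here.

Three measured compounds share one core and differ only in the acyl part of the ester. Compound 1 `CCCC(=O)OCc1ccc2oc(=O)c(C(=O)Oc3cccc(Br)c3)cc2c1` gives 88.6% in a functional assay on HT-1080 cells (Homo sapiens), read by transwell migration, with a stated time of 24 h, tested at 0.1 uM; on this read-out higher numbers stand for a weaker effect at the one concentration tested and lower numbers for a stronger effect. Compound 2 `CCCCC(=O)OCc1ccc2oc(=O)c(C(=O)Oc3cccc(Br)c3)cc2c1` gives 92.4% in this assay; the step of a number 3.8 percentage points higher from compound 1 to compound 2 (within the scatter) stays within the scatter. Compound 3 `CC(C)C(=O)OCc1ccc2oc(=O)c(C(=O)Oc3cccc(Br)c3)cc2c1` gives 54.4%, the lowest of the three numbers; the steps of a number 34.2 percentage points lower from compound 1 to compound 3 (beyond the scatter) and a number 38 percentage points lower from compound 2 to compound 3 (beyond the scatter) are both large and beyond the scatter.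

Compound 4 `CC(C)(C)C(=O)OCc1ccc2oc(=O)c(C(=O)Oc3cccc(Br)c3)cc2c1` is not yet measured. It differs from compound 3 by methyl in place of hydrogen on a saturated chain carbon bound to a carbonyl carbon and two saturated chain carbons. Among the compounds with values here, no measured step adds a methyl at such a carbon: the step from compound 1 to compound 2 adds a methyl further along a chain and stays within the scatter, while the two steps toward compound 3 lower the number strongly. Without a direct precedent, the expectation for this assay is a step of a number 4.4 percentage points lower from compound 3 to compound 4 (within the scatter), not clearly beyond the scatter in either direction. Compound 4 is therefore estimated at 50%, with a range from 25% to 85%.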

Compound 4, a percentage reported as activity, at one concentration (the size of the read-out at that concentration, not a potency): 65.2%
For compound 4 the middle estimate is 15.2 percentage points below the measured one, within the range that was stated.
By their numbers in this assay, from the lowest: compound 3; then compound 4; then compounds 1 and 2 (each within the scatter of the next).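

In this assay, branching at the carbon bound to the carbonyl carbon still gives a lower number with tert-butyl in place of the straight chains: a number 23.4 percentage points lower from compound 1 to compound 4 (beyond the scatter) and a number 27.2 percentage points lower from compound 2 to compound 4 (beyond the scatter), so the drop is not confined to the isopropyl ester. The added methyl does not extend that drop, and the series turns back up at this position, with a number 10.8 percentage points higher from compound 3 to compound 4 (beyond the scatter), leaving compound 3 lowest of the four. Read as one change, adding a methyl raises the number by a comparable amount at both places on the acyl chain, as far as two steps can show: the same change on two cores in this assay, a number 3.8 percentage points higher (within the scatter) from compound 1 to compound 2 and a number 10.8 percentage points higher (beyond the scatter) from compound 3 to compound 4, 7 percentage points apart, within the scatter of two such steps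

From the compounds shown here alone, whether a ring-closed branch, such as a cyclopropylcarbonyl ester, would follow isopropyl or tert-butyl remains open. So does the reading of an amine or a carboxylic acid on the acyl chain.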